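This account rests on a few compounds, and the source may have more. Where it says the series, first, only, none or still open, it means among the compounds named here.

This account covers a small set of analogues sharing one core and tested in a functional assay on HT-29 cells (Homo sapiens) for cytotoxicity, read by MTT assay, with a stated time of 72 h; a higher number here means a weaker inhibitor, a lower number a stronger inhibitor. Compound 1 `COc1cc2c(Oc3ccc(NC(=O)c4cc(-c5ccccc5)ccn4)cc3F)ccnc2cc1OCCCN1CCCC1` gives 120 nM in this assay. Compound 2 `COc1cc2c(Oc3ccc(NC(=O)c4cc(-c5ccccc5C)ccn4)cc3F)ccnc2cc1OCCCN1CCCC1` gives 1150 nM in this assay. The two differ only by methyl in place of hydrogen on an aromatic carbon, and this change produced a 9.6-fold higher number from compound 1 to compound 2 (0.98 log units; beyond the scatter). Compound 3 `COc1cc2c(Oc3ccc(NC(=O)c4nccc(-c5ccccc5)n4)cc3F)ccnc2cc1OCCCN1CCCCC1` gives 260 nM in this assay; it stands second highest of the three numbers, nearest to compound 1 and furthest from compound 2. The difference between the core of compound 3 and the core of compound 1 is not broken down here.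

Compound 4 `COc1cc2c(Oc3ccc(NC(=O)c4nccc(-c5ccc(C)cc5)n4)cc3F)ccnc2cc1OCCCN1CCCCC1` has not yet been measured in this assay. It differs from compound 3 by methyl in place of hydrogen on an aromatic carbon. This is the same kind of change as that from compound 1 to compound 2, but not the same: in compound 2 the methyl sits ortho to a large group, whereas in compound 4 it sits para to a large group. Going by the values given here, the only measured example of this kind of change is a 9.6-fold higher number from compound 1 to compound 2 (0.98 log units; beyond the scatter), which points to a higher number. Among the compounds with values here, because a 9.6-fold higher number from compound 1 to compound 2 (0.98 log units; beyond the scatter) is the sole precedent and was measured with the methyl ortho to a large group rather than para to a large group, the step is expected to be smaller, estimated as a 1.7-fold higher number from compound 3 to compound 4 (0.24 log units; within the scatter) in this assay. Compound 4 is therefore estimated at 450 nM, with a likely range from 150 nM to 1500 nM.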

Compound 4, half-maximal inhibitory concentration: 620 nM
Beside the measured number, compound 4's estimate is 1.4-fold (0.14 log units) below it; the range from low to high includes it.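

In this assay, putting methyl in place of hydrogen on the core of compound 3 gives a 2.4-fold higher number from compound 3 to compound 4 (0.38 log units; beyond the scatter), so the two available examples of this change both move the number in the same direction. The size of the step, however, did not carry over from one core to the other: the same change on two cores in this assay, a 9.6-fold higher number (0.98 log units; beyond the scatter) from compound 1 to compound 2 and a 2.4-fold higher number (0.38 log units; beyond the scatter) from compound 3 to compound 4, 4.0-fold (0.60 log units) apart, beyond the scatter of two such steps. This does not show what sets the size of the step, since the two pairs differ in their cores and the methyl also stands in a different place, para to a large group in compound 4 but elsewhere on the ring in compound 2, and two examples cannot separate these differences or establish a rule for the series.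

From the compounds shown here alone, it remains open whether a methyl para to a large group on the core of compound 1 would give a step closer to that from compound 3 to compound 4, and whether a methyl in the place it holds in compound 2 would give a larger step on the core of compound 3. Also open, going by these compounds, is how other groups at the position para to a large group, such as a chlorine or an amine, would read in this assay.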